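Methoxy for methyl on the phenyl ring of compound 2

The source may hold more compounds than are shown below. What is called first, only, known or untested is meant among the compounds shown, and "the series" means these compounds.

Measured so far in a physicochemical assay for solubility, read by HPLC, using the shake flask method, measured as kinetic solubility, with a stated time of 2 h, at pH 7.4; a lower number here means a less soluble compound, a higher number a more soluble compound:
- Compound 1 `Cc1cc(NCc2ccccn2)n2nc(C)c(-c3ccc(F)cc3)c2n1` gives < 5000 nM, which is a limit of the assay rather than a number.
- Compound 2 `Cc1ccc(-c2cnn3c(NCc4ccccn4)cc(C)nc23)cc1` gives < 5000 nM, also a limit of the assay.
- Compound 3 `Cc1cc(NCc2nccn2C)n2nc(C)c(-c3ccccc3)c2n1` gives 26900 nM.

Among the compounds with values here, compound 2 therefore stands at the limit of < 5000 nM in this assay, at which 2 of the 3 values shown sit, so only a ceiling is known for it, and compound 3 is the one compound of the three with a measured number in this assay.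

Compound 4 `COc1ccc(-c2cnn3c(NCc4ccccn4)cc(C)nc23)cc1` differs from compound 2 in one place: methoxy in place of methyl on an aromatic carbon. Within the data shown here, no measured pair of compounds shows this particular exchange, so there is no directly comparable step to lean on. The expectation is that compound 4 remains near the ceiling of compound 2, with at most a modest upward shift, if any, beyond the scatter; the step implied by the estimate is a number no lower from compound 2 to compound 4 (the limit leaves the size open). Compound 4 is thus estimated at 5000 nM, within a range of 1500 nM to 20000 nM, and it may well again be reported only as a limit.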

Compound 4, solubility: < 5000 nM
Compound 4 gave a limit, no number; the forecaster's own chance of this, stated with the estimate: 55%; the middle value sits exactly at the limit.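

In this assay compound 4 gives < 5000 nM as a limit and not a number. Compound 2 also sits at a limit, so no step can be read between compound 2 and compound 4. The compounds shown leave open how far the 4-methylphenyl and 4-methoxyphenyl compounds actually lie apart.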